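The compounds below may be only part of what the source reports. "The series", "measured", "known", "first", "only" and "open" are said of these compounds alone.

The measured compounds in this study:

compound 1, `CCCc1ccc(NC2=CC(=O)c3nc4n(c3C2=O)[C@H]2OC[C@@H](O)[C@H]2OC4)cc1`: 4990 nM
compound 2, `O=C1C=C(NCc2ccccc2)C(=O)c2c1nc1n2[C@H]2OC[C@@H](O)[C@H]2OC1`: a limit, > 8000 nM
compound 3, `O=C1C(NCc2ccccc2)=CC(=O)c2c1nc1n2[C@H]2OC[C@@H](O)[C@H]2OC1`: 11000 nM

All three were tested in a functional assay on HeLa cells (Homo sapiens) for inhibition, read by sulforhodamine B assay; a lower number here means a stronger inhibitor, a higher number a weaker inhibitor. Compound 1 gives 4990 nM. For compound 2 the assay reports only a limit, not a number, > 8000 nM; this is the limit of > 8000 nM in this assay, at which 1 of the 3 values shown sits. Compound 3 gives 11000 nM, the higher of the two numbers, and its gap to compound 1 lies beyond the usual scatter.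

Compounds 2 and 3 are built from the same atoms joined differently; the difference between the two cores is not broken down here. Compound 1 differs from compound 2 in one place: 4-propylphenyl in place of benzyl on an amine nitrogen. That change produced an at least 1.6-fold lower number from compound 2 to compound 1 (0.20 log units; that floor lies within the scatter), and since the starting point is a limit, only a floor for the step is known.

Compound 4, `CCCc1ccc(NC2=CC(=O)c3c(nc4n3[C@H]3OC[C@@H](O)[C@H]3OC4)C2=O)cc1`, is not yet measured in this assay. It stands to compound 3 exactly as compound 1 stands to compound 2: 4-propylphenyl in place of benzyl on an amine nitrogen. The surroundings of the place are the same in both cases, so this is the same change. For compound 4 a step of a similar size is expected, because the same change on the other core gave an at least 1.6-fold lower number from compound 2 to compound 1 (0.20 log units; that floor lies within the scatter). This estimate means an expected step of a 2.0-fold lower number from compound 3 to compound 4 (0.30 log units; within the scatter). Compound 4 is therefore expected at 5500 nM, with a plausible range from 2500 nM to 12000 nM.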

Compound 4, half-maximal inhibitory concentration: 6030 nM
The estimate for compound 4 lay 1.1-fold (0.04 log units) below the measured number; the measured number falls inside the stated range.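

In this assay, putting 4-propylphenyl in place of benzyl on an amine nitrogen gave a 1.8-fold lower number from compound 3 to compound 4 (0.26 log units; within the scatter), so on this core the change is not shown to do more than repeated measurement alone could produce. Set beside the same change on the other core, this result is compatible with the change carrying over from one core to the other, but it does not show that the step keeps the same size on both: the same change on two cores in this assay, an at least 1.6-fold lower number (0.20 log units; that floor lies within the scatter) from compound 2 to compound 1 and a 1.8-fold lower number (0.26 log units; within the scatter) from compound 3 to compound 4; the limit leaves it open whether they differ. Compound 2 is reported as a limit, not a number: the limit of > 8000 nM in this assay, at which 1 of the 4 values shown sits.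

The compounds shown leave open whether any other group on that amine nitrogen, such as a phenyl ring bearing a longer chain, an amine or a carboxylic acid in place of propyl, would give a step beyond the scatter on either core. Among the compounds shown here, they also leave open whether the two cores would respond alike to such a group, since the one pair that could be compared on both cores rests on a single swap, and one of its two steps is known only as a floor.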